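Sulfonyl substituent swap on the methylpiperidinyl-piperidine sulfonamide core

The compounds below may be only part of what the source reports. "The series", "measured", "known", "first", "only" and "open" are said of these compounds alone.

These notes follow the step from compound 2 to compound 4 within a small set sharing one sulfonamide core. The anchor is compound 1 `CC1CCN(C2CCN(S(=O)(=O)c3cccc(-c4ccccc4C(F)(F)F)c3)CC2)CC1`, which in a functional assay on DLD-1 cells (Homo sapiens) for antiproliferative activity, read by CellTiter-Glo, with a stated time of 72 h (a lower number here means a stronger inhibitor, a higher number a weaker inhibitor), gives 10 nM. Compound 2 `CC1CCN(C2CCN(S(=O)(=O)c3cn(C)cn3)CC2)CC1` carries the same core with a different group on the sulfonyl sulfur. In this assay compound 2 reaches only the limit of the measurement, > 5000 nM, so no number is known for it. Compound 3 `Cc1cc(C)c(S(=O)(=O)N2CCC(C3OCC(C)CO3)CC2)c(C)c1`, built on another core, likewise gives only a limit in this assay, > 5000 nM. Thus of the three values shown, compound 1 is the one with a number, and the other two sit at the limit of > 5000 nM in this assay, at which 2 of the 3 values shown sit; compound 2 therefore stands at the weak end of what is shown, with its true value unknown beyond the limit.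

Compound 4 `CCc1ccc(S(=O)(=O)N2CCC(N3CCC(C)CC3)CC2)cc1` differs from compound 2 by the change (4-ethylphenyl in place of 1-methyl-1H-imidazol-4-yl on a sulfonyl sulfur). Among the compounds with values here, no step between measured compounds on this core isolates that change. Since compound 1 carries a six-membered carbon ring on the same sulfur and gives 10 nM, a move back toward a measurable value is expected for compound 4, well beyond the scatter. The step from compound 2 to compound 4 is expected to be an at least 33-fold lower number from compound 2 to compound 4 (1.52 log units; beyond the scatter). For compound 4 the estimate is 150 nM, with a range from 30 nM to 1500 nM.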

Compound 4, half-maximal inhibitory concentration: > 5000 nM
Compound 4 ended at the assay's limit; the forecaster's own chance of this, stated with the estimate: 10%; middle value at least 33-fold (1.52 log units) away from the limit.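

In this assay compound 2 and compound 4 both give only a limit, so no step between them can be read: the limit of > 5000 nM in this assay, at which 3 of the 4 values shown sit.

The compounds shown leave open the true values of compound 2 and compound 4, and whether 4-ethylphenyl and 1-methyl-1H-imidazol-4-yl on the sulfonyl sulfur differ at all in their effect on activity.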